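The source may hold more compounds than are shown below. What is called first, only, known or untested is meant among the compounds shown, and "the series" means these compounds.

Measured compounds in a functional assay on ileum for inhibition of histamine H1 receptor (Cavia porcellus); a higher number here means a weaker inhibitor, a lower number a stronger inhibitor: compound 1, `CCNCCn1c(N2CCN(C)CC2)nc2ccccc21`, gives 290 nM; compound 2, `CCCOCCn1c(N2CCN(C)CC2)nc2ccccc21`, gives 20 nM; compound 3, `CCCCOCCn1c(N2CCN(C)CC2)nc2ccccc21`, gives 38 nM.

Compound 3 stands second highest of the three numbers; the nearest step is a 1.9-fold higher number from compound 2 to compound 3 (0.28 log units; within the scatter), within the scatter, while the furthest is a 7.6-fold lower number from compound 1 to compound 3 (0.88 log units; beyond the scatter), beyond it. Compound 4, `CCCC(C)n1c(N2CCN(C)CC2)nc2ccccc21`, carries 1-methylbutyl in place of 2-butoxyethyl on an aromatic nitrogen. The steps bearing on the chain are a 15-fold lower number from compound 1 to compound 2 (1.16 log units; beyond the scatter) and a 7.6-fold lower number from compound 1 to compound 3 (0.88 log units; beyond the scatter), both beyond the scatter, so the chain composition two bonds from the aromatic nitrogen clearly sets the number, whereas a 1.9-fold higher number from compound 2 to compound 3 (0.28 log units; within the scatter) shows chain length alone hardly matters. Going by the values given here, no measured step removes the oxygen, so the direction is open; a modest weakening is expected rather than none. Compound 4 is estimated at 80 nM (range 20 nM to 320 nM), an expected step of a 2.1-fold higher number from compound 3 to compound 4 (0.32 log units; beyond the scatter).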

Compound 4, half-maximal inhibitory concentration: 1400 nM
Beside the measured number, compound 4's estimate is 18-fold (1.24 log units) below it, and the stated range ends below it.
By their numbers in this assay, from the lowest: compounds 2 and 3 (each within the scatter of the next); then compound 1; then compound 4.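

Replacing 2-butoxyethyl with 1-methylbutyl on the aromatic nitrogen gives a 37-fold higher number from compound 3 to compound 4 (1.57 log units; beyond the scatter) and replacing 2-propoxyethyl with it gives a 70-fold higher number from compound 2 to compound 4 (1.85 log units; beyond the scatter) so this position clearly responds to more than the small chain-length change among the ethers. Even against the 2-(ethylamino)ethyl chain there is a 4.8-fold higher number from compound 1 to compound 4 (0.68 log units; beyond the scatter) which leaves compound 4 the weakest inhibitor of the four. Nothing available here explains the loss.

This change removes the chain oxygen and introduces branching at the carbon on the nitrogen together. Going by these compounds, whether an unbranched pentyl chain would track compound 3 or compound 4 remains open.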